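Chromone ether series: sigma-1 binding, cyclobutyl to pyridinyl

The source may report more compounds than this note shows. Statements on the series, on what has been measured and on what is new or still open speak of the compounds shown alone.

Measured compounds:
compound 1 `O=c1cc(-c2ccccc2)oc2ccc(OCCCCCCN3CCCCC3)cc12` — 101 nM
compound 2 `O=c1cc(-c2ccccc2)oc2ccc(OCCCCCCN3CCNC(CCO)C3)cc12` — 63 nM
compound 3 `O=c1cc(C2CCC2)oc2ccc(OCCCCCCN3CCCCC3)cc12` — 51 nM

In an assay on isolated protein (Cavia porcellus) with Sigma non-opioid intracellular receptor 1 (Homo sapiens) as the target, read by radioligand binding (on this read-out lower numbers stand for stronger inhibition and higher numbers for weaker inhibition), compound 3 holds the lowest of the three numbers, but its gaps to the others are small: compound 2 sits within the scatter of it, and compound 1 lies at a 2.0-fold lower number from compound 1 to compound 3 (0.30 log units; within the scatter). The two measured steps both stay inside the scatter: a 1.6-fold lower number from compound 1 to compound 2 (0.20 log units; within the scatter) and a 2.0-fold lower number from compound 1 to compound 3 (0.30 log units; within the scatter). Neither step moves the read-out beyond repeat-to-repeat variation.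

Compound 4 `O=c1cc(-c2cccnc2)oc2ccc(OCCCCCCN3CCCCC3)cc12` arises from compound 3 by the change (pyridin-3-yl in place of cyclobutyl on an aromatic carbon); the new group is placed next to the ring oxygen, meta to a fused ring, meta to a group of 1 heavy atom and para to a fused ring. Going by the values given here, only the step from compound 1 to compound 3 bears on this site, and it was within the scatter, so the aromatic phenyl of compound 1 and the cyclobutyl of compound 3 read about the same. Pyridin-3-yl, an aromatic ring like phenyl, is therefore expected to land between those two values, with no step beyond the scatter: a 1.8-fold higher number from compound 3 to compound 4 (0.25 log units; within the scatter). For compound 4 the expected value in this assay is 90 nM, with a range of 35 nM to 250 nM.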

Compound 4, half-maximal inhibitory concentration: 119 nM
Beside the measured number, compound 4's estimate is 1.3-fold (0.12 log units) below it, within the range that was stated.
By their numbers in this assay, from the lowest: compounds 3, 2, 1 and 4 (each within the scatter of the next, the first and the last beyond it).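

In this assay, this position gives its first step beyond the scatter: a 2.3-fold higher number from compound 3 to compound 4 (0.37 log units; beyond the scatter), a modest change, with pyridin-3-yl entering for cyclobutyl on the aromatic carbon next to the ring oxygen. The swap of phenyl for pyridin-3-yl at the same carbon gives a 1.2-fold higher number from compound 1 to compound 4 (0.07 log units; within the scatter), so exchanging one six-membered aromatic ring for the other, which adds one ring nitrogen and one hydrogen-bond acceptor, leaves the read-out within repeat-to-repeat variation, and the separation at this site appears only between cyclobutyl and pyridin-3-yl, while a 2.0-fold lower number from compound 1 to compound 3 (0.30 log units; within the scatter) keeps cyclobutyl and phenyl within the scatter of each other. Nothing available explains the step from cyclobutyl to pyridin-3-yl.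

The compounds shown leave open whether the step reflects ring size or aromaticity, which a cyclohexyl or cyclopentyl group at this carbon would help to separate, and whether the placing of the ring nitrogen matters, as pyridin-2-yl or pyridin-4-yl would show. Also open, as far as these compounds go, is whether the step holds with 3-(2-hydroxyethyl)piperazin-1-yl in place of piperidin-1-yl on the chain.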